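The source may hold more compounds than are shown below. What is called first, only, known or untested is meant among the compounds shown, and "the series" means these compounds.

Measured so far in an ADME assay on the whole organism (Rattus norvegicus, strain Sprague-Dawley) for pharmacokinetics, read by LC-MS, with a stated time of 30 min; on this read-out lower numbers stand for narrower distribution and higher numbers for wider distribution into tissues:
- compound 1 `N#Cc1ccc(O[C@H]2CN(S(=O)(=O)c3ccc(Cl)cc3)C[C@@]2(O)CO)cc1F`: 6 L/kg
- compound 2 `N#Cc1ccc(O[C@H]2CN(S(=O)(=O)c3ccc(C(F)(F)F)nc3)C[C@@]2(O)CO)cc1F`: 4.1 L/kg
- compound 3 `N#Cc1ccc(O[C@H]2CN(S(=O)(=O)c3ccc(C(F)(F)F)cc3C#N)C[C@@]2(O)CO)cc1F`: 3.6 L/kg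

Compound 1 gives the highest of the three numbers, yet its separation from compound 2 and compound 3 stays within the scatter; compound 3, whose ring on the sulfonyl sulfur also carries a nitrile, gives 3.6 L/kg. Compound 4 `N#Cc1ccc(O[C@H]2CN(S(=O)(=O)c3ccccc3C#N)C[C@@]2(O)CO)cc1F` differs from compound 1 by 2-cyanophenyl in place of 4-chlorophenyl on a sulfonyl sulfur. Going by the values given here, the one directly comparable step, an exchange of the aryl on the sulfonyl sulfur, is a 1.5-fold lower number from compound 1 to compound 2 (0.17 log units; within the scatter). Nothing in the series shows this position shifting the number beyond the scatter, so compound 4 is expected to land near compound 1. The step expected is a 1.3-fold lower number from compound 1 to compound 4 (0.12 log units; within the scatter). Compound 4 is therefore estimated at 4.5 L/kg, with a range of 2.3 L/kg to 8.5 L/kg.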

Compound 4, volume of distribution at steady state in the Rattus norvegicus assay: 0.9 L/kg
Compound 4: the middle estimate sits 5.0-fold (0.70 log units) above what was measured; the measured number lies below the stated range.
By their numbers in the Rattus norvegicus assay, from the lowest: compound 4; then compounds 3, 2 and 1 (each within the scatter of the next).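

In the Rattus norvegicus assay the aryl on the sulfonyl sulfur can move the number beyond the scatter, as seen in a 6.7-fold lower number from compound 1 to compound 4 (0.82 log units; beyond the scatter) and in a 4.6-fold lower number from compound 2 to compound 4 (0.66 log units; beyond the scatter) and, with hydrogen in place of trifluoromethyl and the nitrile kept, in a 4.0-fold lower number from compound 3 to compound 4 (0.60 log units; beyond the scatter). A nitrile alone therefore does not set the low number, since compound 3 carries one too. In a physicochemical assay for solubility, in simulated intestinal fluid, with a stated time of 4 h (a lower number here means a less soluble compound, a higher number a more soluble compound), compound 1 gives 44 ug/mL and compound 4 gives 20 ug/mL, but nothing shown accounts for the narrower distribution.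

Open, going by these compounds, is whether the low number belongs to 2-cyanophenyl itself or to any aryl without trifluoromethyl or chlorine. Plain phenyl, or an amine or carboxylic acid on that ring, would separate these.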